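Removing the carbamate and lengthening the ester chain

The source may report more compounds than this note shows. Statements on the series, on what has been measured and on what is new or still open speak of the compounds shown alone.

Compound 1 `CC(C)(C)OC(=O)NCCCC(=O)O[C@H]1[C@H](O)[C@@H](CO)O[C@H]1n1cc(/C=C/Br)c(=O)[nH]c1=O` gives 55000 nM in an assay on isolated protein for inhibition of thymidine kinase 2, mitochondrial (Homo sapiens); on this read-out lower numbers stand for stronger inhibition and higher numbers for weaker inhibition.
Compound 2 `CC(C)(C)OC(=O)NCCCCCCCCCCCC(=O)O[C@H]1[C@H](O)[C@@H](CO)O[C@H]1n1cc(/C=C/Br)c(=O)[nH]c1=O` gives 3800 nM in this assay.
Compound 3 `CCCCCCCC(=O)O[C@H]1[C@H](O)[C@@H](CO)O[C@H]1n1cc(C)c(=O)[nH]c1=O` gives 120000 nM in this assay.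

All three compounds share a sugar core carrying an ester chain, and they differ mainly in that chain. Among the three numbers, compound 1 stands second highest: compound 3 sits above it by a gap beyond the scatter, and compound 2 sits below it by a much larger gap, also beyond the scatter.

Compound 4 `NCCCCCC(=O)O[C@H]1[C@H](O)[C@@H](CO)O[C@H]1n1cc(/C=C/Br)c(=O)[nH]c1=O` is the compound still to be measured. Relative to compound 1 it shows (2-aminoethyl in place of (tert-butoxycarbonyl)amino on a saturated chain carbon, three bonds along the chain from a carbonyl carbon). The chain is thereby shortened at its end and the capping group is gone, while the ester itself is kept.

The expected step from compound 1 to compound 4 in this assay is a 1.6-fold higher number from compound 1 to compound 4 (0.21 log units; within the scatter), a modest move toward weaker inhibition, but one that may well stay within the scatter. For compound 4 the estimated value is 90000 nM, with a likely range from 25000 nM to 350000 nM.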

Compound 4, half-maximal inhibitory concentration: > 500000 nM
Compound 4: only a limit was reported; the forecaster's own chance of this, stated with the estimate: 30%; middle value at least 5.5-fold (0.74 log units) away from the limit.
By their numbers in this assay, from the lowest: compound 2; then compound 1; then compound 3. At a limit, above all of these: compound 4.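

In this assay, putting 2-aminoethyl in place of (tert-butoxycarbonyl)amino on a saturated chain carbon, three bonds along the chain from a carbonyl carbon, gives an at least 9.0-fold higher number from compound 1 to compound 4 (0.95 log units; beyond the scatter). For the compounds shown here, the value of compound 4 is a limit of the assay, not a number: the limit of > 500000 nM in this assay, at which 1 of the 4 values shown sits. The earlier compounds offered no pair differing in one place, and this step is the first direct sign that inhibition responds to what sits at this end of the ester chain, with the ester itself kept.

The change removes the capping group and alters the chain length together, and the compounds shown do not separate these two effects. A free amine on a chain the length of that in compound 1, a (tert-butoxycarbonyl)amino group on the chain of compound 4, or a longer chain ending in an amine or a carboxylic acid could each help to tell them apart.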